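Moving two chlorines around the outer phenyl ring

The source may report more compounds than this note shows. Statements on the series, on what has been measured and on what is new or still open speak of the compounds shown alone.

Three compounds share a core built on the structure of compound 1, `O=C(/C=C/c1ccc(Cl)c([N+](=O)[O-])c1)/C=C/c1ccccc1Oc1ncnc2ccc(Cl)cc12`, and were tested in a functional assay on MGC-803 cells (Homo sapiens) for inhibition, read by MTT assay, with a stated time of 72 h; on this read-out lower numbers stand for stronger inhibition and higher numbers for weaker inhibition. Compound 1 gives 5320 nM. Compound 2, `O=C(/C=C/c1ccc(Oc2ncnc3ccc(Cl)cc23)cc1)/C=C/c1c(Cl)cccc1Cl`, gives 6770 nM, and compound 3, `O=C(/C=C/c1ccccc1Oc1ncnc2ccc(Cl)cc12)/C=C/c1c(Cl)cccc1Cl`, gives 5170 nM; the value of compound 2 sits within the scatter of both compound 1 and compound 3. Compound 4, `O=C(/C=C/c1ccc(Oc2ncnc3ccc(Cl)cc23)cc1)/C=C/c1ccc(Cl)c(Cl)c1`, is not yet measured. It differs from compound 2 by 3,4-dichlorophenyl in place of 2,6-dichlorophenyl on a double-bonded chain carbon bound to a double-bonded chain carbon. Within the data shown here, the one step that touches the same place, a 1.0-fold lower number from compound 1 to compound 3 (0.01 log units; within the scatter), changed 4-chloro-3-nitrophenyl into 2,6-dichlorophenyl with no shift beyond the scatter. Among the measured compounds shown here, no measured pair compares a 2,6-dichlorophenyl with a 3,4-dichlorophenyl, so the direction of the step in this assay is open, and the expectation is a step of about a 1.1-fold lower number from compound 2 to compound 4 (0.05 log units; within the scatter), that is, none beyond the scatter. Compound 4 is therefore estimated at 6000 nM, expected to fall between 2500 nM and 14000 nM.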

Compound 4, half-maximal inhibitory concentration: 16900 nM
Compound 4: middle estimate off by 2.8-fold (0.45 log units), on the low side; the whole stated range lies below it.
By their numbers in this assay, from the lowest: compounds 3, 1 and 2 (each within the scatter of the next); then compound 4.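

Placing 3,4-dichlorophenyl where 2,6-dichlorophenyl stood gives, in this assay, a 2.5-fold higher number from compound 2 to compound 4 (0.40 log units; beyond the scatter), which means weaker inhibition. The two groups have the same atoms, so moving the two chlorines around the ring is enough on its own to shift the result, something the earlier change at this place, a 1.0-fold lower number from compound 1 to compound 3 (0.01 log units; within the scatter), gave no sign of. No available measurement explains the shift.

As far as these compounds go, it remains open whether the same change of chlorine placement would have a similar effect in the arrangement of the shared core seen in compound 3. From the compounds shown here alone, it is also open how a methoxyphenyl or an aminophenyl group would compare with the two dichlorophenyl groups at this place.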